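This account rests on a few compounds, and the source may have more. Where it says the series, first, only, none or still open, it means among the compounds named here.

Measured so far in a physicochemical assay for solubility, read by nephelometry, measured as kinetic solubility; a lower number here means a less soluble compound, a higher number a more soluble compound: compound 1 `COc1cc(Nc2nc(C)cc(N(C)C)n2)ccc1F` gives > 250000 nM, which is a limit of the measurement rather than a number. Compound 2 `COc1cc(OC)cc(C(=O)N[C@H]2CC[C@H](Nc3nc(C)cc(N(C)C)n3)CC2)c1` gives > 250000 nM, also a limit. Compound 3 `COc1cc(Nc2nccc(N(C)C)n2)ccc1F` gives 160000 nM.

Going by the values given here, compound 3 therefore stands as the only true number among the three; the other two sit at the limit of > 250000 nM in this assay, at which 2 of the 3 values shown sit. Compound 4 `COc1cc(Nc2nc(CO)cc(N(C)C)n2)ccc1F` differs from compound 3 by hydroxymethyl in place of hydrogen on an aromatic carbon. Among the compounds with values here, the one measured step at this same position is an at least 1.5-fold lower number from compound 1 to compound 3 (0.19 log units; that floor lies within the scatter), known only as a floor because the limit of > 250000 nM in this assay, at which 2 of the 3 values shown sit, caps the starting value. That step lies within the scatter, so the hydroxymethyl is expected to move the solubility little, if at all. Compound 4 is estimated at 250000 nM, with a range from 120000 nM to 500000 nM. This estimate means an expected 1.6-fold higher number from compound 3 to compound 4 (0.19 log units; within the scatter).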

Compound 4, solubility: > 250000 nM
Compound 4 ended at the assay's limit; the forecaster's own chance of this, stated with the estimate: 50%; the middle value lies on the limit itself.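

On this aromatic carbon next to the ring nitrogen, hydroxymethyl in place of hydrogen gives an at least 1.5-fold higher number from compound 3 to compound 4 (0.19 log units; that floor lies within the scatter) in this assay. That floor lies within the scatter, and the true size of the change stays hidden; what is new is that a group with a hydrogen-bond donor on this carbon ends at the limit, as the methyl of compound 1 does. The step from compound 1 to compound 4 cannot be read, because both values are limits: the limit of > 250000 nM in this assay, at which 3 of the 4 values shown sit.

As far as these compounds go, what an amine, a carboxylic acid or a longer chain on this carbon would give stays open.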